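The source may hold more compounds than are shown below. What is called first, only, known or untested is meant among the compounds shown, and "the series" means these compounds.

Working notes on the series.

Among the measured compounds shown here, compound 2 `Cc1nn(C)c(Oc2cccc(Cl)c2)c1/C=N\CCCCCCOc1cc2oc(=O)cc(C)c2cc1Cl` is the only member of the set with a number in a functional assay on HepG2 cells (Homo sapiens) for antiproliferative activity, read by MTT assay, with a stated time of 72 h; on this read-out higher numbers stand for weaker inhibition and lower numbers for stronger inhibition: compound 2 gives 6220 nM. Compound 1 `Cc1nn(C)c(Oc2ccccc2F)c1/C=N\CCCCCCOc1cc2oc(=O)cc(C)c2cc1Cl` reaches only a limit in this assay, where compound 1 is recorded as > 25000 nM; this is the limit noted in the limit of > 25000 nM in this assay, at which 1 of the 2 values shown sits. For the measured compounds named here, the one measured step, an at least 4.0-fold lower number from compound 1 to compound 2 (0.60 log units; beyond the scatter), moves a halogen on the phenyl ring on the ether oxygen and is the only guide available.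

Compound 3 `Cc1nn(C)c(Oc2ccc(I)cc2)c1/C=N\CCCCCCOc1cc2oc(=O)cc(C)c2cc1Cl` differs from compound 2 by 4-iodophenyl in place of 3-chlorophenyl on an oxygen on an aromatic ring, a change of both the halogen and its position on that ring. The measured step shows that this region can shift this assay by a modest amount, but in which direction a heavier halogen at a new position will move the number is not settled by the data. Compound 3 is therefore expected to stay near compound 2, with an estimated step of a 1.2-fold lower number from compound 2 to compound 3 (0.09 log units; within the scatter), giving an estimate of 5000 nM with a range from 1500 nM to 20000 nM.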

Compound 3, half-maximal inhibitory concentration: 14200 nM
Estimate against measurement, compound 3: 2.8-fold (0.45 log units) below, within the range that was stated.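

In this assay, 4-iodophenyl in place of 3-chlorophenyl on an oxygen on an aromatic ring gives a 2.3-fold higher number from compound 2 to compound 3 (0.36 log units; beyond the scatter), so this change weakens inhibition and compound 2 keeps the lowest number of the three. Measured against compound 1, the step is only a floor, an at least 1.7-fold lower number from compound 1 to compound 3 (0.24 log units; that floor lies within the scatter), which does not firmly separate compound 3 from compound 1. Compound 1 stands at a limit and not at a number: the limit of > 25000 nM in this assay, at which 1 of the 3 values shown sits.

The halogen and its place on the ring change together from compound 2 to compound 3, so the compounds shown cannot tell the two contributions apart. From the compounds shown here alone, how an amine or a carboxylic acid on that phenyl ring, or a longer chain on the core, would read in this assay also remains open.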